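A few compounds are considered here, and "the series" means these few. Any claim that something is new, unique, unknown or untested is made for them only; others in the source may bear on it.

Compound 1 is `NS(=O)(=O)c1ccc(NC(=S)Nc2ccc3ncnc(Nc4cccc(C(F)(F)F)c4)c3c2)cc1` and compound 2 is `Cc1cccc(Nc2ncnc3ccc(NC(=S)Nc4ccc(S(N)(=O)=O)cc4)cc23)c1`; the two share one core. In a functional assay on NCI-H1975 cells (Homo sapiens) for antiproliferative activity, read by MTT assay, with a stated time of 72 h (a lower number here means a stronger inhibitor, a higher number a weaker inhibitor), compound 1 gives 7590 nM, and compound 2 gives 35400 nM. Compound 2 therefore stands at the higher of the two numbers, separated from compound 1 by a 4.7-fold higher number from compound 1 to compound 2 (0.67 log units; beyond the scatter), a change of methyl in place of trifluoromethyl on an aromatic carbon. The next compound, compound 3, is `Cc1ccc(Nc2ncnc3ccc(NC(=S)Nc4ccc(S(N)(=O)=O)cc4)cc23)cc1`. It differs from compound 2 by 4-methylphenyl in place of 3-methylphenyl on a nitrogen on an aromatic ring: the same atoms, joined differently, with the methyl placed elsewhere on the ring attached to the nitrogen. Among the measured compounds shown here, no measured step covers such a shift of a methyl within the ring; the only step in hand, a 4.7-fold higher number from compound 1 to compound 2 (0.67 log units; beyond the scatter), concerns an exchange of the group itself and was modest. For the measured compounds named here, with no direct precedent, the expected step in this assay is none beyond the scatter, and the estimate for compound 3 is a 1.1-fold higher number from compound 2 to compound 3 (0.05 log units; within the scatter). Compound 3 is therefore expected to give about 40000 nM, within a range of 12000 nM to 130000 nM.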

Compound 3, half-maximal inhibitory concentration: 39400 nM
For compound 3 the middle estimate is 1.0-fold (0.01 log units) above the measured one; measured number inside the range.
By their numbers in this assay, from the lowest: compound 1; then compounds 2 and 3 (each within the scatter of the next).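

Shifting the methyl from 3-methylphenyl to 4-methylphenyl on the nitrogen gives a 1.1-fold higher number from compound 2 to compound 3 (0.05 log units; within the scatter) in this assay, so the two placements of the methyl cannot be told apart here. The separation from the trifluoromethyl compound therefore does not depend on which of these two placements the methyl takes: the exchange of 3-(trifluoromethyl)phenyl for 4-methylphenyl gives a 5.2-fold higher number from compound 1 to compound 3 (0.72 log units; beyond the scatter) and, like a 4.7-fold higher number from compound 1 to compound 2 (0.67 log units; beyond the scatter), lies beyond the scatter. Nothing available explains either the match between the two methyl compounds or their separation from compound 1.

The compounds shown leave open how a group other than methyl or trifluoromethyl on this ring, such as a chlorine atom, a methoxy group or an amine, would read in this assay, and whether trifluoromethyl itself would read the same from the other placement. They also leave open how far the sulfonamide-bearing side of the shared core can be altered, for example by a carboxylic acid in place of the sulfonamide, while the ring on the nitrogen stays fixed.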